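Two Fluorinated Dienones Point to a Third

A few compounds are considered here, and "the series" means these few. Any claim that something is new, unique, unknown or untested is made for them only; others in the source may bear on it.

Measured compounds:
Compound 1, `CC1=CCCC(C)(C)C1/C=C/C(=O)/C=C/c1ccccc1F`, gives 9400 nM in a functional assay on CWR22R cells (Homo sapiens) for cytotoxicity, read by MTT assay, with a stated time of 72 h; a lower number here means a stronger inhibitor, a higher number a weaker inhibitor.
Compound 2, `CC1=CCCC(C)(C)C1/C=C/C(=O)/C=C/c1cc(C(F)(F)F)ccc1F`, gives 3500 nM in this assay.
Compound 3, `CC1=C(/C=C/C(=O)/C=C/c2cccc(C(F)(F)F)c2)C(C)(C)CCC1O`, gives 1700 nM in this assay.

Among these three, compound 3 gives the lowest number, and its steps to compound 2 and compound 1 are both beyond the usual scatter, so it is the strongest inhibitor of the measured set. Compound 2 differs from compound 1 in one place: trifluoromethyl in place of hydrogen on an aromatic carbon. That change gave a 2.7-fold lower number from compound 1 to compound 2 (0.43 log units; beyond the scatter).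

Compound 4, `CC1=C(/C=C/C(=O)/C=C/c2cc(C(F)(F)F)cc(C(F)(F)F)c2)C(C)(C)CCC1O`, has not yet been measured. It differs from compound 3 in one place: trifluoromethyl in place of hydrogen on an aromatic carbon. The core of compound 3 and the core of compound 1 differ from each other, and that difference is not broken down here. Among the measured compounds shown here, the change from compound 3 to compound 4 is the same kind of change as the one from compound 1 to compound 2, though the surroundings are not the same: in compound 2 the entering group sits para to a fluoro group, whereas in compound 4 it sits meta to a trifluoromethyl group.

Resting on the step from compound 1 to compound 2, compound 4 is expected to show a 1.9-fold lower number from compound 3 to compound 4 (0.28 log units; within the scatter) in this assay, somewhat smaller than that earlier step since the surroundings differ. The estimate for compound 4 is 900 nM, expected to lie between 400 nM and 2500 nM.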

Compound 4, half-maximal inhibitory concentration: 2200 nM
The estimate for compound 4 lay 2.4-fold (0.39 log units) below the measured number, and the stated range covers the measured number.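

In this assay, trifluoromethyl in place of hydrogen on an aromatic carbon gave a 1.3-fold higher number from compound 3 to compound 4 (0.11 log units; within the scatter), so on the core of compound 3 this change produced no effect that can be told apart from ordinary repeat-to-repeat variation. The change therefore did not carry over with the same size from the core of compound 1, where it gave a real step, to the core of compound 3: the same change on two cores in this assay, a 2.7-fold lower number (0.43 log units; beyond the scatter) from compound 1 to compound 2 and a 1.3-fold higher number (0.11 log units; within the scatter) from compound 3 to compound 4, 3.5-fold (0.54 log units) apart, beyond the scatter of two such steps This does not show what sets the two steps apart, as the two pairs differ in their core and also in the other groups on the aromatic ring, and with a single pair on each core these differences cannot be separated, nor can a rule for the whole series be drawn.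

The compounds shown leave open whether a different group at the same place on compound 3, such as a methoxy group, an amine or a carboxylic acid, would move the number beyond the scatter. Among the compounds shown here, also open is which part of the difference between the two cores matters, as no pair here changes the core while keeping the aromatic ring the same.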